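Adding a second chloro to a dichloro purine core

A few compounds are considered here, and "the series" means these few. Any claim that something is new, unique, unknown or untested is made for them only; others in the source may bear on it.

Compound 1 `ClCc1ccccc1Cn1cnc2c(Cl)nc(Cl)nc21` gives 3090 nM in a functional assay on CAKI-1 cells (Homo sapiens) for cytotoxicity, read by sulforhodamine B assay, with a stated time of 48 h; a lower number here means that less compound is tolerated, a higher number that more compound is tolerated.
Compound 2 `ClCc1ccccc1Cn1cnc2c(Cl)ncnc21` gives 9330 nM in this assay.
Compound 3 `ClCc1ccccc1Cn1cnc2ncnc(Cl)c21` gives 7410 nM in this assay.

Compound 1 and compound 2 share a core and differ by one change, (chloro in place of hydrogen on an aromatic carbon); this gave a 3.0-fold lower number from compound 2 to compound 1 (0.48 log units; beyond the scatter). Compound 3 has the same atoms as compound 2 joined differently; the difference between the two cores is not broken down here. Compound 4 `ClCc1ccccc1Cn1cnc2nc(Cl)nc(Cl)c21`, not yet measured, arises from compound 3 by chloro in place of hydrogen on an aromatic carbon, the same change as that from compound 2 to compound 1, at a place described in the same words. Resting on that single earlier step, compound 4 is expected to show a step of about a 3.0-fold lower number from compound 3 to compound 4 (0.47 log units; beyond the scatter) in this assay. Compound 4 is therefore estimated at 2500 nM, likely between 1200 nM and 6000 nM.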

Compound 4, concentration lethal to 50% of the cells: 61700 nM
The estimate for compound 4 lay 25-fold (1.39 log units) below the measured number; the measured number lies above the stated range.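

Putting the chloro on the core of compound 3 gave an 8.3-fold higher number from compound 3 to compound 4 (0.92 log units; beyond the scatter), which runs the opposite way to the earlier step on the other core: the same change on two cores in this assay, a 3.0-fold lower number (0.48 log units; beyond the scatter) from compound 2 to compound 1 and an 8.3-fold higher number (0.92 log units; beyond the scatter) from compound 3 to compound 4, 25-fold (1.40 log units) apart, beyond the scatter of two such steps

So in this series, the effect of this change did not carry from one core to the other, even though the change reads the same on both. Going by these compounds alone, with only two such pairs, this shows that the outcome can differ with the core, but it does not show why, or which way the change would go on a further core.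

The compounds shown carry only hydrogen or chloro on the aromatic carbon between two ring nitrogen atoms. Going by these compounds, how an amine or a methoxy group at that place would behave on either core remains open.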